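Indole replacement on the butyl-piperazine series: nitrile analogue

A few compounds are considered here, and "the series" means these few. Any claim that something is new, unique, unknown or untested is made for them only; others in the source may bear on it.

Two compounds of the series carry a measured number. Compound 1 `Cc1cccc2c1ccn2CCCCN1CCN(C(c2ccccc2)c2ccccc2)CC1` gives 5300 nM in an assay on RPMI-8226 cells for antagonist activity at P2X purinoceptor 7 (Homo sapiens), read by calcium flux; a higher number here means a weaker inhibitor, a lower number a stronger inhibitor. Compound 2 `Cc1cccc2ccn(CCCCN3CCN(C(c4ccccc4)c4ccccc4)CC3)c12` gives 2300 nM in this assay and stands as the lower of the two numbers; the step of a 2.3-fold lower number from compound 1 to compound 2 (0.36 log units; beyond the scatter) separates them. The only shown step therefore concerns moving a methyl within the indole, with no other change to the shared core.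

Compound 3 `N#Cc1cn(CCCCN2CCN(C(c3ccccc3)c3ccccc3)CC2)c2ccccc12` is not yet measured. Relative to compound 2 the change is a group of 11 heavy atoms (9 carbon, 2 nitrogen; one five-membered aromatic ring with 1 hetero atom, one six-membered aromatic ring of carbon only) in place of a group of 10 heavy atoms (9 carbon, 1 nitrogen; one five-membered aromatic ring with 1 hetero atom, one six-membered aromatic ring of carbon only), on a saturated chain carbon, four bonds along the chain from an amine nitrogen in a ring, so the entering group carries a nitrile in place of the methyl. Among the measured compounds shown here, no measured step touches a nitrile on this ring, and the step from compound 1 to compound 2 bears on it only loosely, as a sign that changes on the indole can shift the number modestly. Within this series the indole appears to tolerate small changes without large swings, but only compound 1 and compound 2 support that.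

The working expectation is that the shift a 1.1-fold higher number from compound 2 to compound 3 (0.04 log units; within the scatter) stays modest and of uncertain direction. Compound 3 is estimated at 2500 nM, with a range from 700 nM to 9000 nM.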

Compound 3, half-maximal inhibitory concentration: 1500 nM
For compound 3 the middle estimate is 1.7-fold (0.22 log units) above the measured one; the range from low to high includes it.
By their numbers in this assay, from the lowest: compounds 3 and 2 (each within the scatter of the next); then compound 1.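

The step of a 1.5-fold lower number from compound 2 to compound 3 (0.19 log units; within the scatter) in this assay shows that, at this place on the saturated chain, a group carrying a nitrile can stand in for 7-methyl-1H-indol-1-yl without a step beyond the scatter, so compounds 2 and 3 cannot be ranked against each other. The step of a 3.5-fold lower number from compound 1 to compound 3 (0.55 log units; beyond the scatter) shows that the nitrile-bearing group, like the group of compound 2, also separates from the group of compound 1 by more than the scatter, so compound 1 stays apart from both other compounds in this small set. No measurement bears on why the numbers fall as they do, and the change in the group's count of hydrogen-bond acceptors cannot be linked to the result.

The compounds shown leave open whether the nitrile itself matters, as they do not separate its presence from the loss of the methyl, and a group with neither, or one carrying a carboxylic acid or an amine instead, would bear on that. They also leave open whether the same result would hold on a longer chain.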